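Trimming the tert-butyl: one methyl less on the azepanone

The source may report more compounds than this note shows. Statements on the series, on what has been measured and on what is new or still open speak of the compounds shown alone.

Compound 1 `CC(C)(C)C1CCNC(=O)C(N(Cc2ccc(C(=O)NC3CC3)cc2)S(=O)(=O)c2ccc(Cl)cc2)C1`: 110 mL.min-1.g-1
Compound 2 `O=C(NC1CC1)c1ccc(CN([C@@H]2CC(F)(F)CCNC2=O)S(=O)(=O)c2ccc(Cl)cc2)cc1`: 2.2 mL.min-1.g-1

In an in vitro ADME assay on microsomes from liver (Mus musculus) for pharmacokinetics (a lower number here means slower removal, a higher number faster removal of the compound), compound 1 gives the higher of the two numbers shown; compound 2 sits far below it, as a 50-fold lower number from compound 1 to compound 2 (1.70 log units; beyond the scatter) shows. Compound 3 `CC(C)C1CCNC(=O)C(N(Cc2ccc(C(=O)NC3CC3)cc2)S(=O)(=O)c2ccc(Cl)cc2)C1` differs from compound 1 by a single change: hydrogen in place of methyl on a saturated chain carbon bound to two saturated chain carbons and a saturated ring carbon, tert-butyl to isopropyl. Among the measured compounds shown here, the one measured step replaces the whole group at once, so it bears only loosely on this smaller cut. The writer expects a modest drop for compound 3, a 1.6-fold lower number from compound 1 to compound 3 (0.20 log units; within the scatter), and estimates 70 mL.min-1.g-1, within 30 mL.min-1.g-1 to 150 mL.min-1.g-1.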

Compound 3, intrinsic clearance in microsomes: 203 mL.min-1.g-1
For compound 3 the middle estimate is 2.9-fold (0.46 log units) below the measured one; the measured number lies above the stated range.
By their numbers in this assay, from the lowest: compound 2; then compounds 1 and 3 (each within the scatter of the next).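

Taking off this one methyl, tert-butyl to isopropyl, does not separate the two compounds in this assay: the step is a 1.8-fold higher number from compound 1 to compound 3 (0.27 log units; within the scatter) and stays within the scatter. The large gap to the 5,5-difluoro compound survives the smaller alkyl group, as a 92-fold higher number from compound 2 to compound 3 (1.97 log units; beyond the scatter) shows. Nothing given here explains either step.

The compounds shown leave open where a smaller group on this ring carbon, such as ethyl, methyl or a hydroxyl, would fall. From the compounds shown here alone, it also remains open whether a single fluorine would sit nearer compound 2 or nearer compound 1 and compound 3.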